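Urea terminus on the proline amide: compound 4 outlook

The compounds below may be only part of what the source reports. "The series", "measured", "known", "first", "only" and "open" are said of these compounds alone.

Measured compounds in an assay on isolated protein for binding affinity to secreted frizzled-related protein 1 (Homo sapiens), read by fluorescence; a higher number here means a weaker inhibitor, a lower number a stronger inhibitor:
- compound 1, `O=C(CN1CCCC1)N1CCC(NS(=O)(=O)c2cc(S(=O)(=O)c3ccccc3)ccc2C(F)(F)F)CC1`: 110 nM
- compound 2, `CC(C)(C)OC(=O)N1CCC[C@H]1C(=O)N1CCC(NS(=O)(=O)c2cc(S(=O)(=O)c3ccccc3)ccc2C(F)(F)F)CC1`: 60 nM
- compound 3, `CCNC(=O)N1CCC[C@H]1C(=O)N1CCC(NS(=O)(=O)c2cc(S(=O)(=O)c3ccccc3)ccc2C(F)(F)F)CC1`: 30 nM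

Compound 3 holds the lowest number of the three in this assay. Its margin over compound 2 is small, a 2.0-fold lower number from compound 2 to compound 3 (0.30 log units; within the scatter), whereas the gap back to compound 1, a 3.7-fold lower number from compound 1 to compound 3 (0.56 log units; beyond the scatter), is beyond the scatter, so compound 3 is separated only from compound 1.

Compound 4, `CN(C)C(=O)N1CCC[C@H]1C(=O)N1CCC(NS(=O)(=O)c2cc(S(=O)(=O)c3ccccc3)ccc2C(F)(F)F)CC1`, has not been measured. It differs from compound 3 only at the carbonyl carbon of the carbamoyl group: dimethylamino in place of ethylamino on a carbonyl carbon.

Going by the values given here, the one measured step at this same carbonyl carbon, a 2.0-fold lower number from compound 2 to compound 3 (0.30 log units; within the scatter), stayed within the scatter even though the whole group on that carbon was exchanged. The larger change at the amide, a 3.7-fold lower number from compound 1 to compound 3 (0.56 log units; beyond the scatter), was modest. On this basis the exchange of ethylamino for dimethylamino is expected to move the number little, if at all, beyond the scatter, with any shift more likely upward than downward; the expected step is a 1.5-fold higher number from compound 3 to compound 4 (0.18 log units; within the scatter).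

Compound 4 is therefore estimated at 45 nM in this assay, within a range of 20 nM to 110 nM.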

Compound 4, half-maximal inhibitory concentration: 30 nM
Estimate against measurement, compound 4: 1.5-fold (0.18 log units) above; the measured number falls inside the stated range.
By their numbers in this assay, from the lowest: compounds 3, 4, 2 and 1 (each within the scatter of the next, the first and the last beyond it).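

Working notes: in this assay, the step of no change at the digits printed from compound 3 to compound 4 (within the scatter) shows that this carbonyl carbon accepts dimethylamino, with no hydrogen-bond donor, as readily as ethylamino, with one, so the amide hydrogen of the ethylcarbamoyl group is not required for this level of binding. The step of a 2.0-fold lower number from compound 2 to compound 4 (0.30 log units; within the scatter) leaves the dimethylcarbamoyl and tert-butoxycarbonyl compounds unseparated, as the ethylcarbamoyl and tert-butoxycarbonyl compounds already were. The step of a 3.7-fold lower number from compound 1 to compound 4 (0.56 log units; beyond the scatter) shows that the separation from the (pyrrolidin-1-yl)methyl compound holds with a second carbamoyl group, not only with ethylcarbamoyl.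

Still open, from the compounds shown here alone, is whether a cyclic amine such as morpholine, or a longer alkyl chain on the nitrogen, would hold the number at this carbonyl carbon. No measured evidence is available to explain this tolerance.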